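The compounds below may be only part of what the source reports. "The series", "measured", "known", "first", "only" and "open" are said of these compounds alone.

Working notes on the series. Among the compounds with values here, compound 1 `CC(C)N(O)C(=O)NCCCSc1nc2ccccc2s1` gives 70 nM in a functional assay for inhibition of Polyunsaturated fatty acid 5-lipoxygenase (Homo sapiens) (on this read-out lower numbers stand for an effect already at smaller amounts and higher numbers for an effect only at larger amounts of compound), the lowest of the two numbers so far. Compound 2 `O=C(NO)NCCSc1nc2cc(Cl)ccc2s1` gives 24500 nM in this assay, a far higher number, beyond the scatter. Compound 3 `CN(O)C(=O)NCCCSc1nc2ccccc2s1` is not yet measured. It differs from compound 1 by a single change, (methyl in place of isopropyl on an amide-type nitrogen). Within the data shown here, no measured pair differing in one place exists here, so this step has no precedent. Expected is a small rise, close to the edge of the scatter, as the step of a 2.1-fold higher number from compound 1 to compound 3 (0.33 log units; beyond the scatter). Compound 3 is estimated at 150 nM, within 40 nM to 600 nM.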

Compound 3, half-maximal effective concentration: 45 nM
Beside the measured number, compound 3's estimate is 3.3-fold (0.52 log units) above it; low and high end bracket the measured number.
By their numbers in this assay, from the lowest: compounds 3 and 1 (each within the scatter of the next); then compound 2.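

Methyl and isopropyl on the amide-type nitrogen are not told apart in this assay: the step is a 1.6-fold lower number from compound 1 to compound 3 (0.19 log units; within the scatter). Within the data shown here, this position therefore accepts either group with no change beyond the scatter, a point the earlier compounds, which differ in more than one place, could not show. Nothing at hand bears on why the two groups read alike.

From the compounds shown here alone, whether a benzyl group or a carboxylic acid on this nitrogen would keep the number in this range stays open. Also open, going by these compounds, is how a longer chain in place of the propyl link would read.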